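Chloro in place of trifluoromethoxy on the aryl ring

The source may report more compounds than this note shows. Statements on the series, on what has been measured and on what is new or still open speak of the compounds shown alone.

Measured compounds:
Compound 1, `Cn1cnc(C(=O)N(Cc2cccc(OC(F)(F)F)c2)C[C@H]2[C@@H]3CN(CC4CC4)C[C@@H]32)c1`: 2.32 nM
Compound 2, `CN1C[C@@H]2[C@H](C1)[C@H]2CN(Cc1cccc(OC(F)(F)F)c1)C(=O)c1cn(C)cn1`: 2.32 nM

Both values come from an assay on isolated protein for binding affinity to sodium- and chloride-dependent glycine transporter 1 (Homo sapiens); a higher number here means a weaker inhibitor, a lower number a stronger inhibitor. Compound 2 stands level with compound 1 at the digits shown; the one measured step, no change at the digits printed from compound 1 to compound 2 (within the scatter), is hydrogen in place of cyclopropyl on a saturated chain carbon bound to an amine nitrogen in a ring, and it lies within the scatter.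

Compound 3, `CN1C[C@@H]2[C@H](C1)[C@H]2CN(Cc1cccc(Cl)c1)C(=O)c1cn(C)cn1`, has not yet been measured in this assay. It differs from compound 2 by chloro in place of trifluoromethoxy on an aromatic carbon. Within the data shown here, no measured step touches the aromatic ring or its substituent, so nothing here shows how that position responds. The estimate therefore rests on compound 2 alone, with a widened range; a step of a 2.2-fold higher number from compound 2 to compound 3 (0.33 log units; beyond the scatter) is expected, leaning slightly toward weaker binding. For compound 3 the expected value in this assay is 5 nM, within 1.5 nM to 18 nM.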

Compound 3, inhibition constant: 11 nM
Beside the measured number, compound 3's estimate is 2.2-fold (0.34 log units) below it; the range from low to high includes it.
By their numbers in this assay, from the lowest: compounds 1 and 2 (each within the scatter of the next); then compound 3.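

In this assay the aromatic substituent proves to be a sensitive place: chloro in place of trifluoromethoxy gives a 4.7-fold higher number from compound 2 to compound 3 (0.68 log units; beyond the scatter) and so moves the number beyond the scatter, which the change at the amine nitrogen, no change at the digits printed from compound 1 to compound 2 (within the scatter), did not do. The swap replaces a group of 5 heavy atoms and 1 hydrogen-bond acceptor with a single chlorine, and this one step cannot separate those differences. Nothing measured here accounts for the step.

Going by these compounds, it remains open whether a trifluoromethyl, methoxy or fluoro group on this aromatic carbon would read closer to compound 2 or to compound 3. On these data alone, it is also open whether the same exchange would shift the number by as much with the cyclopropyl group of compound 1 in place.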